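The source may hold more compounds than are shown below. What is called first, only, known or untested is meant among the compounds shown, and "the series" means these compounds.

Measured compounds:
compound 1 `CCc1cccc(NC(=O)CN2CCN(c3ccccn3)CC2)c1` gives 67.9 nM in an assay on HEK293 cells for displacement of a labelled ligand from D(4) dopamine receptor (Homo sapiens), read by scintillation counting, with a stated time of 60 min; a lower number here means a stronger inhibitor, a higher number a weaker inhibitor;
compound 2 `O=C(CN1CCN(c2ccccn2)CC1)Nc1cncnc1` gives 39300 nM in this assay.

Within the data shown here, compound 2 stands at the higher of the two numbers; the only comparison available, a 580-fold higher number from compound 1 to compound 2 (2.76 log units; beyond the scatter), is large and beyond the scatter, and compound 2 is the weaker inhibitor of the pair. Compound 3 `Cc1cccc(NC(=O)CN2CCN(c3ccccn3)CC2)c1` is not yet measured. It differs from compound 2 by 3-methylphenyl in place of pyrimidin-5-yl on an amide-type nitrogen. Among the measured compounds shown here, the single measured step that bears on this change is the one in the opposite direction, a 580-fold higher number from compound 1 to compound 2 (2.76 log units; beyond the scatter), where a carbon-only ring on the amide-type nitrogen was replaced by pyrimidin-5-yl. Compound 3 reverses that replacement, though with 3-methylphenyl rather than 3-ethylphenyl, so a large move back toward the number of compound 1 is expected, a 440-fold lower number from compound 2 to compound 3 (2.64 log units; beyond the scatter). Compound 3 is therefore estimated to give 90 nM, within a range of 30 nM to 300 nM.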

Compound 3, inhibition constant: 212 nM
For compound 3 the middle estimate is 2.4-fold (0.37 log units) below the measured one, and the stated range covers the measured number.
By their numbers in this assay, from the lowest: compound 1; then compound 3; then compound 2.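

In this assay, the large loss seen with pyrimidin-5-yl on the amide-type nitrogen is not particular to 3-ethylphenyl, since a second carbon-only ring gives a similar contrast, with a 190-fold lower number from compound 2 to compound 3 (2.27 log units; beyond the scatter). The new compound also shows that the chain on that ring matters in its own right: going from ethyl to methyl, with hydrogen in place of methyl on the saturated chain carbon, gives a 3.1-fold higher number from compound 1 to compound 3 (0.49 log units; beyond the scatter), a modest step next to the change of ring. No evidence is given that explains either step.

Compounds 2 and 3 differ both in the ring nitrogens and in the methyl group, so the shares of these two features stay unresolved, and a plain phenyl or a pyridinyl ring would separate them. As far as these compounds go, whether a longer chain such as propyl continues the trend from methyl to ethyl also remains open.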